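The compounds below may be only part of what the source reports. "The series", "measured", "known", "first", "only" and "open" are said of these compounds alone.

Measured so far:
- compound 1, `O=C([C@H]1Cc2cc(Cl)cc(-c3ccnc4cc(CO)sc34)c2O1)N1CCNCC1`; in an assay on isolated protein for inhibition of ubiquitin carboxyl-terminal hydrolase 47 (Homo sapiens) (on this read-out higher numbers stand for weaker inhibition and lower numbers for stronger inhibition), compound 1 gives > 40000 nM, which is a limit of the assay, not a number.
- compound 2, `O=C([C@H]1Cc2cc(Cl)cc(-c3ccnc4cc(C5(O)COC5)sc34)c2O1)N1CCNCC1`; in this assay compound 2 gives > 40000 nM, again a limit of the assay and not a number.

Where compound 2 stands: only a limit is known for compound 2, and the same holds for the one other value shown, so that (the limit of > 40000 nM in this assay, at which 2 of the 2 values shown sit). Within the data shown here, the single measured step, a step that the two limits leave unreadable from compound 1 to compound 2, is therefore unreadable in size and direction; the two limits give no information on what exchanging one small hydroxylated group for another does here.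

The next compound, compound 3, `O=C([C@H]1Cc2cc(Cl)cc(-c3ccnc4cc(C(O)(CO)CCl)sc34)c2O1)N1CCNCC1`, differs from compound 2 by 1-(chloromethyl)-1,2-dihydroxyethyl in place of 3-hydroxyoxetan-3-yl on an aromatic carbon. Among the measured compounds shown here, no measured step bears on this change, since the only step cannot be read. With both measured compounds sitting at the limit, the expectation for the step from compound 2 to compound 3 is none beyond the scatter, i.e. a number no higher from compound 2 to compound 3 (the limit leaves the size open), and compound 3 is expected most likely to report a limit as well. Estimate for compound 3 in this assay: 40000 nM, with a range from 15000 nM to 100000 nM.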

Compound 3, half-maximal inhibitory concentration: > 40000 nM
Compound 3 ended at the assay's limit (the forecaster's own chance of this, stated with the estimate: 85%); the middle value sits exactly at the limit.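

No new step can be read between compound 1, compound 2 and compound 3, since all of them stand at a limit of the assay rather than at a number: the limit of > 40000 nM in this assay, at which 3 of the 3 values shown sit.

The compounds shown leave open whether hydroxymethyl, 3-hydroxyoxetan-3-yl and 1-(chloromethyl)-1,2-dihydroxyethyl differ at all in inhibition, and whether any group at this place next to the ring sulfur gives a measurable value.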